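A few compounds are considered here, and "the series" means these few. Any claim that something is new, unique, unknown or untested is made for them only; others in the source may bear on it.

Among the measured compounds shown here, compound 3, `COc1cccc(CNCCCNc2ccnc3cc(Cc4cccc(C(F)(F)F)c4)ccc23)c1O`, is one of three compounds measured in a physicochemical assay for solubility, with a stated time of 18 h, at pH 7.4; on this read-out higher numbers stand for higher solubility and lower numbers for lower solubility. In this assay compound 3 gives 4200 nM, and it stands level with compound 1, `COc1cccc(CNCCCNc2ccnc3cc(C4CCCCC4)ccc23)c1O`, which gives 4200 nM; the two together are the lowest of the three numbers, and the step of no change at the digits printed from compound 1 to compound 3 (within the scatter) confirms that nothing separates them. Compound 2, `COc1cccc(CNCCCNc2ccnc3cc(-c4ccc(C(C)(C)C)cc4)ccc23)c1O`, gives 32000 nM, and the step of a 7.6-fold lower number from compound 2 to compound 3 (0.88 log units; beyond the scatter) puts compound 3 well below it.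

Compound 4, `COc1ccc(Oc2ccc3c(NCCCNCc4cccc(OC)c4O)ccnc3c2)cc1`, has not yet been measured. The change from compound 3 is 4-methoxyphenoxy in place of 3-(trifluoromethyl)benzyl on an aromatic carbon. For the measured compounds named here, two measured steps bear on this change. The step of a 7.6-fold lower number from compound 2 to compound 3 (0.88 log units; beyond the scatter) shows that swapping one aromatic substituent for another at this position can move the number by a modest but real amount, while the step of no change at the digits printed from compound 1 to compound 3 (within the scatter) shows that such a swap can also leave it unchanged. Since the incoming 4-methoxyphenoxy group brings two hydrogen-bond acceptors where the outgoing 3-(trifluoromethyl)benzyl group has none, and since compound 2 with its directly attached aromatic ring gives 32000 nM, a modest rise is expected, though a step of no more than the scatter cannot be excluded. The expected step is a 3.3-fold higher number from compound 3 to compound 4 (0.52 log units; beyond the scatter). Compound 4 is therefore estimated at 14000 nM, with a likely range from 5000 nM to 40000 nM.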

Compound 4, solubility: 14500 nM
Compound 4: the middle estimate sits 1.0-fold (0.02 log units) below what was measured; low and high end bracket the measured number.
By their numbers in this assay, from the lowest: compounds 1 and 3 (each within the scatter of the next); then compound 4; then compound 2.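

In this assay, among the compounds shown here, 4-methoxyphenoxy on this aromatic carbon stands apart from 3-(trifluoromethyl)benzyl (a 3.5-fold higher number from compound 3 to compound 4 (0.54 log units; beyond the scatter)) and from cyclohexyl (a 3.5-fold higher number from compound 1 to compound 4 (0.54 log units; beyond the scatter)), the two groups that the earlier compounds could not tell apart. For the compounds shown here, it also stays short of 4-(tert-butyl)phenyl (a 2.2-fold lower number from compound 2 to compound 4 (0.34 log units; beyond the scatter)), so the position now shows an intermediate level, and the four groups fall on three separate levels where the earlier compounds showed only two. Nothing at hand accounts for these differences, so the steps stand as observations without an explanation.

As far as these compounds go, whether the level of compound 4 goes with the methoxy group or with the rest of the 4-methoxyphenoxy group stays open, and a plain phenoxy group would speak to that, as a morpholine or a carboxylic acid on this aromatic carbon would test how far the range of the position extends. From the compounds shown here alone, whether the same steps would hold with a longer chain elsewhere on the shared core also stays open.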